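Moving the halogen on a cyclopentyl ketone acid

The source may report more compounds than this note shows. Statements on the series, on what has been measured and on what is new or still open speak of the compounds shown alone.

Compound 1 `Cc1c(OCCCCOc2ccc(C(=O)O)cc2F)ccc(C(=O)CC2CCCC2)c1O` carries a cyclopentyl group on the saturated chain carbon bound to the carbonyl carbon. In an assay on HEK293 cells for positive allosteric modulation of metabotropic glutamate receptor 3 (Rattus norvegicus), read by thallium flux, with a stated time of 2.5 min (on this read-out higher numbers stand for an effect only at larger amounts of compound and lower numbers for an effect already at smaller amounts), compound 1 gives only a limit, > 10000 nM, the edge of what the assay reports rather than a number. It thus stands at the limit of > 10000 nM in this assay, at which 1 of the 3 values shown sits. Compound 2 `Cc1c(OCCCCOc2ccc(C(=O)O)cc2F)ccc(C(=O)CC(C)C)c1O` has isopropyl in place of cyclopentyl, and in this assay compound 2 gives 1420 nM. That is an at least 7.0-fold lower number from compound 1 to compound 2 (0.84 log units; beyond the scatter). Compound 3 `Cc1c(OCCCCOc2ccc(C(=O)O)cc2Cl)ccc(C(=O)CC(C)C)c1O` has chloro in place of fluoro on an aromatic carbon, and in this assay compound 3 gives 1140 nM. That is a 1.2-fold lower number from compound 2 to compound 3 (0.10 log units; within the scatter). Compound 4 `Cc1c(OCCCCOc2ccc(C(=O)O)c(Cl)c2)ccc(C(=O)CC2CCCC2)c1O` keeps the cyclopentyl group of compound 1 and differs from it by 4-carboxy-3-chlorophenyl in place of 4-carboxy-2-fluorophenyl on an oxygen on a saturated carbon. Among the compounds with values here, the only measured halogen exchange, from compound 2 to compound 3, stayed within the scatter, and no measured pair changes the ring carbon that carries the halogen. With the cyclopentyl group kept, compound 4 is expected to remain at the limit, estimated at 15000 nM with a range of 5000 nM to 50000 nM, so the expected step is a step that the limit leaves unreadable from compound 1 to compound 4.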

Compound 4, half-maximal effective concentration: 2250 nM
Beside the measured number, compound 4's estimate is 6.7-fold (0.82 log units) above it; the whole stated range lies above it.
By their numbers in this assay, from the lowest: compounds 3, 2 and 4 (each within the scatter of the next). At a limit, above all of these: compound 1.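

The cyclopentyl group does not by itself hold a compound at the limit: with it kept, 4-carboxy-3-chlorophenyl in place of 4-carboxy-2-fluorophenyl gives an at least 4.4-fold lower number from compound 1 to compound 4 (0.64 log units; beyond the scatter). This change swaps the halogen and also changes the ring carbon that carries it, whereas the swap on the same ring carbon gave only a 1.2-fold lower number from compound 2 to compound 3 (0.10 log units; within the scatter). The full size of the new step cannot be read because compound 1 gives a limit and not a number: the limit of > 10000 nM in this assay, at which 1 of the 4 values shown sits.

The compounds shown do not separate the halogen from the ring carbon that carries it, as a fluoro or bromo group on the ring carbon that holds chloro in compound 4 would. Also open, on these data alone, is how 4-carboxy-3-chlorophenyl behaves with isopropyl in place of cyclopentyl.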